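This account rests on a few compounds, and the source may have more. Where it says the series, first, only, none or still open, it means among the compounds named here.

Working notes on the series. Compound 3 `COc1ccc(-c2cc3ccccc3nc2/C=C/C(=O)c2ccsc2)cc1` gives in a functional assay on H184B5F5/M10 cells (Homo sapiens) for antiproliferative activity, read by XTT assay, with a stated time of 72 h (a higher number here means a weaker inhibitor, a lower number a stronger inhibitor), a value of 6390 nM. Compound 1 `COc1ccc(-c2cc3ccccc3nc2/C=C/C(=O)c2ccc(OC)cc2OC)cc1` gives 6110 nM and compound 2 `COc1ccc(-c2cc3ccccc3nc2/C=C/C(=O)c2ccccn2)cc1` gives 4140 nM. On these numbers compound 3 carries the highest figure of the three, but the steps of a 1.0-fold higher number from compound 1 to compound 3 (0.02 log units; within the scatter) and a 1.5-fold higher number from compound 2 to compound 3 (0.19 log units; within the scatter) both lie within the scatter, so the three are not separated.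

Compound 4 `COc1ccc(-c2cc3ccccc3nc2/C=C/C(=O)c2sccc2N)cc1` follows from compound 3 by 3-aminothiophen-2-yl in place of thiophen-3-yl on a carbonyl carbon. Every measured step in the series exchanges the group on the carbonyl carbon: a 1.5-fold lower number from compound 1 to compound 2 (0.17 log units; within the scatter), a 1.0-fold higher number from compound 1 to compound 3 (0.02 log units; within the scatter) and a 1.5-fold higher number from compound 2 to compound 3 (0.19 log units; within the scatter), each within the scatter. Among the measured compounds shown here, no measured pair adds a hydrogen-bond donor at this place, so the amino group has no precedent here. The expectation for compound 4 in this assay is therefore a step of a 1.1-fold lower number from compound 3 to compound 4 (0.03 log units; within the scatter), none beyond the scatter. The estimate for compound 4 is 6000 nM, within a range from 2500 nM to 14000 nM.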

Compound 4, half-maximal inhibitory concentration: > 10000 nM
Compound 4: a limit, no number; the forecaster's own chance of this, stated with the estimate: 5%; middle value at least 1.6-fold (0.22 log units) away from the limit.
By their numbers in this assay, from the lowest: compounds 2, 1 and 3 (each within the scatter of the next). At a limit, above all of these: compound 4.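

The reading for compound 4 in this assay is a limit of the assay and not a number: the limit of > 10000 nM in this assay, at which 1 of the 4 values shown sits. Even so, it gives the first separation at this position on a carbonyl carbon: an at least 2.4-fold higher number from compound 2 to compound 4 (0.38 log units; beyond the scatter), whereas the floors of an at least 1.5-fold higher number from compound 3 to compound 4 (0.19 log units; that floor lies within the scatter) and an at least 1.6-fold higher number from compound 1 to compound 4 (0.21 log units; that floor lies within the scatter) remain within the scatter. The group on the carbonyl carbon therefore can matter in this assay, but 3-aminothiophen-2-yl is separated only from pyridin-2-yl, and not from thiophen-3-yl or 2,4-dimethoxyphenyl.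

Going by these compounds, the full size of these steps stays open, as does whether the amino group or the change of thiophene attachment accounts for the separation. A plain thiophen-2-yl and a 3-methoxythiophen-2-yl on the carbonyl carbon would tell these two apart.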